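Halogen swap on the piperazine aryl ring of compound 2

The source may hold more compounds than are shown below. What is called first, only, known or untested is meant among the compounds shown, and "the series" means these compounds.

Measured compounds:
compound 1 `Nc1scc(CN2CCN(c3cccc(F)c3F)CC2)c1C(=O)c1ccc(Cl)cc1`, -5.2%
compound 2 `Nc1scc(CN2CCN(c3ccc(F)c(Cl)c3)CC2)c1C(=O)c1ccc(Cl)cc1`, -21%

In a functional assay on CHO cells with adenosine receptor A1 (Homo sapiens) as the target, read by cAMP accumulation and immunoassay, with a stated time of 6 min, tested at 0.1 uM (a higher number here means a weaker effect of the compound at the concentration tested, a lower number a stronger effect), compound 1 gives -5.2%, while compound 2 gives -21%, the lowest of the two numbers. Among the measured compounds shown here, the only step measured so far, a number 15.8 percentage points lower from compound 1 to compound 2 (beyond the scatter), changes the aryl group on the amine nitrogen in a ring as a whole and is beyond the scatter.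

Compound 3 `Nc1scc(CN2CCN(c3ccc(Cl)c(Cl)c3)CC2)c1C(=O)c1ccc(Cl)cc1` differs from compound 2 by a single atom: chloro in place of fluoro on an aromatic carbon. For the measured compounds named here, no measured step exchanges fluoro for chloro on that ring, so the step from compound 1 to compound 2 bears on it only loosely, as a sign that changes to this aryl group move the read-out in this assay by a modest amount. For compound 3 the expected step is a number 2 percentage points lower from compound 2 to compound 3 (within the scatter), with no clear direction. Compound 3 is therefore estimated at -23% in this assay, in a range from -42% to -4%.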

Compound 3, a percentage reported as activity, at one concentration (the size of the read-out at that concentration, not a potency): -13%
Compound 3: middle estimate off by 10 percentage points, on the low side; the measured number falls inside the stated range.
By their numbers in this assay, from the lowest: compounds 2, 3 and 1 (each within the scatter of the next, the first and the last beyond it).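

In this assay, chloro in place of fluoro on this aromatic carbon, para to a large group, gives a number 8 percentage points higher from compound 2 to compound 3 (within the scatter), so the 3-chloro-4-fluorophenyl and 3,4-dichlorophenyl groups cannot be told apart at this position. Against the 2,3-difluorophenyl group, the 3,4-dichlorophenyl group gives a number 7.8 percentage points lower from compound 1 to compound 3 (within the scatter), whereas the 3-chloro-4-fluorophenyl group gave a number 15.8 percentage points lower from compound 1 to compound 2 (beyond the scatter), so only the latter step separates two aryl groups on the piperazine nitrogen beyond the scatter. No evidence is available that bears on this result.

The compounds shown leave open whether a group other than a halogen on this carbon, such as methyl, methoxy or an amine, would give a number beyond the scatter of compound 2. They also leave open how these readings at a single concentration relate to potency.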